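Second benzyl on the aniline nitrogen: compound 3

The source may report more compounds than this note shows. Statements on the series, on what has been measured and on what is new or still open speak of the compounds shown alone.

Measured so far in a functional assay on HT-29 cells (Homo sapiens) for antiproliferative activity, read by MTT assay, with a stated time of 72 h; a higher number here means a weaker inhibitor of growth, a lower number a stronger inhibitor of growth:
compound 1 `Cc1ccc2nc(-c3ccc(N)cc3)cn2c1`: 82900 nM
compound 2 `Cc1ccc2nc(-c3ccc(NCc4ccccc4)cc3)cn2c1`: 8800 nM

Among the measured compounds shown here, compound 2 holds the lowest of the two numbers in this assay; its nearest neighbour is compound 1, and the gap between them is the single measured step, a 9.4-fold lower number from compound 1 to compound 2 (0.97 log units; beyond the scatter).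

Compound 3 `Cc1ccc2nc(-c3ccc(N(Cc4ccccc4)Cc4ccccc4)cc3)cn2c1` differs from compound 2 by benzyl in place of hydrogen on a nitrogen on an aromatic ring. For the measured compounds named here, the only step that bears on this change is a 9.4-fold lower number from compound 1 to compound 2 (0.97 log units; beyond the scatter), which concerns the first benzyl on that nitrogen. Going by the values given here, no measured pair shows what a second benzyl on an already benzylated nitrogen does, so the direction is uncertain; a further gain of the same size cannot be assumed, nor can a loss be excluded.

Compound 3 is therefore expected at 5000 nM, with a range of 1000 nM to 25000 nM. The expected step is a 1.8-fold lower number from compound 2 to compound 3 (0.25 log units; within the scatter), an estimate that leans only slightly below compound 2 and stays close to the scatter.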

Compound 3, concentration for 50% growth inhibition: 37600 nM
The estimate for compound 3 lay 7.5-fold (0.88 log units) below the measured number; measured number outside the range, above it.
By their numbers in this assay, from the lowest: compound 2; then compound 3; then compound 1.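

In this assay the same replacement on this nitrogen runs in opposite directions: the first benzyl gives a 9.4-fold lower number from compound 1 to compound 2 (0.97 log units; beyond the scatter) and the second gives a 4.3-fold higher number from compound 2 to compound 3 (0.63 log units; beyond the scatter) and so gives back part of the earlier gain. Across these compounds the number therefore does not fall steadily with each added benzyl, and compound 2, with a single benzyl and one hydrogen left on the nitrogen, holds the lowest number, with both its steps beyond the scatter. Nothing available accounts for this reversal.

Open, from the compounds shown here alone, is whether the loss follows from the missing hydrogen on the nitrogen or from the second benzyl itself, which a methyl as the second group on the benzylated nitrogen would help separate. Also open, going by these compounds, is how an amide carbonyl on this nitrogen, or a longer chain such as phenethyl in place of benzyl, would behave.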